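Triazole aryl swap on two sesquiterpenoid-derived cores

The source may hold more compounds than are shown below. What is called first, only, known or untested is meant among the compounds shown, and "the series" means these compounds.

Measured compounds:
compound 1 `CC(C)=CCC/C(C)=C/CC/C(C)=C/CC[C@@H]1[C@@]2(C)CC/C(=N\OCc3cn(-c4cccc(Br)c4)nn3)C(C)(C)[C@@H]2CC[C@@]1(C)O`, 39800 nM
compound 2 `CC(C)=CCC/C(C)=C/CC/C(C)=C/CC[C@@H]1[C@@]2(C)CC/C(=N\OCc3cn(-c4ccccc4C#N)nn3)C(C)(C)[C@@H]2CC[C@@]1(C)O`, 21900 nM
compound 3 `CC(C)=CCC/C(C)=C/CC/C(C)=C/CC[C@@H]1[C@@]2(C)C/C(=C\c3ccc(OCc4cn(-c5cccc(Br)c5)nn4)cc3)C(=O)C(C)(C)[C@@H]2CC[C@@]1(C)O`, 23700 nM

In a functional assay on HepG2 cells (Homo sapiens) for cytotoxicity, read by MTT assay, with a stated time of 48 h (a higher number here means a weaker inhibitor, a lower number a stronger inhibitor), compound 1 gives 39800 nM and compound 2 gives 21900 nM. The change between them is 2-cyanophenyl in place of 3-bromophenyl on an aromatic nitrogen, and it gives a 1.8-fold lower number from compound 1 to compound 2 (0.26 log units; within the scatter). Compound 3 gives 23700 nM in this assay. The difference between the core of compound 1 and the core of compound 3 is not broken down here. Compound 4 `CC(C)=CCC/C(C)=C/CC/C(C)=C/CC[C@@H]1[C@@]2(C)C/C(=C\c3ccc(OCc4cn(-c5ccccc5C#N)nn4)cc3)C(=O)C(C)(C)[C@@H]2CC[C@@]1(C)O` is not yet measured; it carries the same change on the core of compound 3, namely (2-cyanophenyl in place of 3-bromophenyl on an aromatic nitrogen). The step is expected to be a 1.6-fold lower number from compound 3 to compound 4 (0.20 log units; within the scatter), resting on a 1.8-fold lower number from compound 1 to compound 2 (0.26 log units; within the scatter) alone, which lies within the scatter. Compound 4 is therefore estimated at 15000 nM, with a range from 6500 nM to 38000 nM.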

Compound 4, half-maximal inhibitory concentration: 63100 nM
For compound 4 the middle estimate is 4.2-fold (0.62 log units) below the measured one; the whole stated range lies below it.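

In this assay, placing 2-cyanophenyl in place of 3-bromophenyl on the core of compound 3 gives a 2.7-fold higher number from compound 3 to compound 4 (0.43 log units; beyond the scatter), so the step seen on the core of compound 1 does not carry over to this core: the same change on two cores in this assay, a 1.8-fold lower number (0.26 log units; within the scatter) from compound 1 to compound 2 and a 2.7-fold higher number (0.43 log units; beyond the scatter) from compound 3 to compound 4, 4.8-fold (0.68 log units) apart, beyond the scatter of two such steps

For these two pairs, the size and direction of the step on one core are therefore no guide to those on the other. The result does not show which part of the two cores lies behind the difference, and one pair on each core gives no rule for the wider series.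

The compounds shown leave open how other groups on the aromatic nitrogen, such as an unsubstituted phenyl, an aminophenyl or a carboxyphenyl, would behave on each core. As far as these compounds go, whether any of them would give the same step on both cores also remains open.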